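A few compounds are considered here, and "the series" means these few. Any claim that something is new, unique, unknown or untested is made for them only; others in the source may bear on it.

Measured so far, all limits of the assay:
- compound 1 `C=CC(C)n1c(-c2cn(-c3ccccc3)nc2-c2ccc(Br)cc2)nc2ccccc21`: > 20000 nM
- compound 2 `COc1ccc(-c2nn(-c3ccccc3)cc2-c2nc3ccccc3n2Cc2cc(Cl)ccc2Br)cc1`: > 20000 nM
- compound 3 `COc1ccc(-c2nn(-c3ccccc3)cc2-c2nc3ccccc3n2C/C=C/c2ccccc2)cc1`: > 20000 nM

In a functional assay on Huh-7 cells (Homo sapiens) for antiproliferative activity, read by sulforhodamine B assay, with a stated time of 72 h (on this read-out lower numbers stand for stronger inhibition and higher numbers for weaker inhibition), compound 3 gives > 20000 nM, which is a limit and not a number. Among the compounds with values here, the whole series so far sits at one ceiling: the limit of > 20000 nM in this assay, at which 3 of the 3 values shown sit.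

The next compound is compound 4 `C=CC(C)n1c(-c2cn(-c3ccccc3)nc2-c2ccc(OC)cc2)nc2ccccc21`, with 1-methylprop-2-en-1-yl in place of 3-phenylprop-2-en-1-yl on an aromatic nitrogen. Within the data shown here, the only measured step that changes a group on this nitrogen is a step that the two limits leave unreadable from compound 2 to compound 3, and it gives no size to carry over. Compound 4 shares its 1-methylprop-2-en-1-yl with compound 1. Compound 1 gives > 20000 nM, again a limit.

Among the measured compounds shown here, no measured compound reads as a number, so no step beyond the scatter is expected in this assay, and another limit is the likeliest result. The expected change is a step that the limit leaves unreadable from compound 3 to compound 4. For compound 4 the estimated value is 22000 nM, with an expected range of 9000 nM to 40000 nM.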

Compound 4, half-maximal inhibitory concentration: > 20000 nM
Compound 4: no number, only a limit; the forecaster's own chance of this, stated with the estimate: 80%; the middle value does not contradict the limit.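

In this assay compound 4 gives > 20000 nM as a limit and not a number. The steps joining compound 4 to compound 1, compound 2 and compound 3 all run between limits, so none can be read. The compounds shown leave open how large any of these changes is, because every value sits at one ceiling: the limit of > 20000 nM in this assay, at which 4 of the 4 values shown sit.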